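Compound 3: Rearranging the Ethylamino Group

The source may report more compounds than this note shows. Statements on the series, on what has been measured and on what is new or still open speak of the compounds shown alone.

Measured in a functional assay on A549 cells (Homo sapiens) for antiproliferative activity, read by MTT assay, with a stated time of 48 h; on this read-out lower numbers stand for stronger inhibition and higher numbers for weaker inhibition:
- Compound 1 `C=C(c1ccc2c(c1)C=CC(C)(C)O2)c1ccc(OC)cc1NC(=O)CN`: 60 nM
- Compound 2 `C=C(c1ccc2c(c1)C=CC(C)(C)O2)c1ccc(OC)cc1NC(=O)CNCC`: 1180 nM

Of these two measurements, compound 2 has the higher number, 1180 nM, and so the weaker inhibition. The next compound, compound 3 `C=C(c1ccc2c(c1)C=CC(C)(C)O2)c1ccc(OC)cc1NC(=O)CN(C)C`, has not yet been measured. It contains the same atoms as compound 2 but joined differently, with dimethylamino in place of ethylamino on a saturated chain carbon bound to a carbonyl carbon.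

Going by the values given here, only one measured step bears on this change: a 20-fold higher number from compound 1 to compound 2 (1.29 log units; beyond the scatter). This large step came with ethyl in place of hydrogen on an amine nitrogen, so changes at this nitrogen can matter in this assay. However, no measured pair compares two carbon-bearing amines directly. Compound 3 also has no hydrogen left on that nitrogen, so compound 2, at 1180 nM, is the closer guide, rather than compound 1.

The expected change is small, with no shift beyond the scatter in either direction: a 1.5-fold lower number from compound 2 to compound 3 (0.17 log units; within the scatter). For compound 3, the estimated value is 800 nM, with an expected range of 250 nM to 2500 nM.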

Compound 3, half-maximal inhibitory concentration: 430 nM
Compound 3: middle estimate off by 1.9-fold (0.27 log units), on the high side; measured number inside the range.
By their numbers in this assay, from the lowest: compound 1; then compound 3; then compound 2.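

In this assay, the change in a 2.7-fold lower number from compound 2 to compound 3 (0.44 log units; beyond the scatter) leaves the count of heavy atoms in the group unchanged, so that count alone does not set the number at this position; how the two carbons sit on the nitrogen also counts. Dimethylamino has no hydrogen-bond donor and ethylamino has one, yet the group without the donor gives the lower number, so losing that hydrogen does not by itself weaken inhibition, while a 7.2-fold higher number from compound 1 to compound 3 (0.86 log units; beyond the scatter) shows that dimethylamino still falls short of the plain amino group of compound 1. No measurement here explains why the two arrangements of the same atoms differ.

Methylamino, with a single carbon on the nitrogen, would show whether one small carbon group already gives much of the rise seen with ethylamino and dimethylamino. Diethylamino or a ring amine such as pyrrolidine would show whether larger groups at this nitrogen keep the order seen among these three compounds, which so far rests on only these groups on one shared core.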